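Adding a second fluoro group to compound 2

The source may hold more compounds than are shown below. What is called first, only, known or untested is meant among the compounds shown, and "the series" means these compounds.

Measured in a functional assay on MCF7 cells (Homo sapiens) for antiproliferative activity, read by MTT assay, with a stated time of 72 h; a higher number here means a weaker inhibitor, a lower number a stronger inhibitor:
Compound 1 `O=S1(=O)C=Cc2cccc(Nc3cccc(C(F)(F)F)c3)c21` gives 750 nM
Compound 2 `O=S1(=O)C=Cc2cccc(Nc3cccc(F)c3)c21` gives 1120 nM

In this assay compound 2 at 1120 nM lies within the scatter of compound 1 at 750 nM and the two cannot be told apart. Compound 3 `O=S1(=O)C=Cc2cccc(Nc3ccc(F)c(F)c3)c21` differs from compound 2 by a single change: fluoro in place of hydrogen on an aromatic carbon with the new group ortho to a fluoro group and para to a large group. Going by the values given here, the only measured step that bears on this is a 1.5-fold higher number from compound 1 to compound 2 (0.17 log units; within the scatter) and it too exchanges a group on an aromatic carbon, here fluoro in place of trifluoromethyl. Among the compounds with values here, no measured step puts a fluoro group where a hydrogen stood, so this support is indirect. In this assay no step beyond the scatter is therefore expected. The estimated size is a 1.1-fold lower number from compound 2 to compound 3 (0.05 log units; within the scatter) and it rests on this one comparison alone. Compound 3 is expected at 1000 nM within a range of 450 nM to 2200 nM on repeat measurement.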

Compound 3, half-maximal inhibitory concentration: 950 nM
Estimate against measurement, compound 3: 1.1-fold (0.02 log units) above; low and high end bracket the measured number.
By their numbers in this assay, from the lowest: compounds 1, 3 and 2 (each within the scatter of the next).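

In this assay, the step that puts a fluoro group where a hydrogen stood, ortho to a fluoro group and para to a large group, is a 1.2-fold lower number from compound 2 to compound 3 (0.07 log units; within the scatter), so compound 2 and compound 3 cannot be told apart. Going by these compounds alone, this is the first direct reading of such a change, since the earlier step only exchanged one group on an aromatic carbon for another, and it shows that this position accepts a fluoro group with no difference that the assay can separate from the scatter. No measurement given here bears on why the second fluoro group leaves the number within the scatter, so the result stands without an explanation.

What the compounds shown leave open is whether a group other than fluoro at this position, such as an amine, a methoxy group or a carboxylic acid, would give a step beyond the scatter. They also leave open how a chlorine atom or a nitrile would read here, and how the ring would read with a hydrogen in place of the fluoro group that compound 2 and compound 3 share.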